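Replacing a phenoxy group with a tert-butylphenyl group

This account rests on a few compounds, and the source may have more. Where it says the series, first, only, none or still open, it means among the compounds named here.

Measured compounds:
- compound 1, `c1ccc(Oc2ccc3c(NCCCNCc4ccco4)ccnc3c2)cc1`: 14500 nM
- compound 2, `COc1cccc(CNCCCNc2ccnc3cc(Oc4ccccc4)ccc23)c1O`: 14500 nM
- compound 3, `COc1ccc(F)cc1CNCCCNc1ccnc2cc(Cc3ccccc3)ccc12`: 4200 nM

In a physicochemical assay for solubility, with a stated time of 18 h, at pH 7.4 (on this read-out lower numbers stand for lower solubility and higher numbers for higher solubility), compound 2 gives 14500 nM, level with compound 1 within the scatter, and together they stand highest of the three numbers. Compound 3 differs from compound 2 in several places, and in this assay compound 3 gives 4200 nM, a clearly lower number. The new compound 4, `COc1cccc(CNCCCNc2ccnc3cc(-c4ccc(C(C)(C)C)cc4)ccc23)c1O`, differs from compound 2 in one place: 4-(tert-butyl)phenyl in place of phenoxy on an aromatic carbon. Within the data shown here, only one measured step is at hand, no change at the digits printed from compound 1 to compound 2 (within the scatter), and it concerns the other end of the molecule, so it does not bear on this change. Nothing measured here covers an exchange at this aromatic carbon. Since the group that enters is larger and carries no hydrogen-bond acceptor, a lower number is expected for compound 4, a step of a 4.8-fold lower number from compound 2 to compound 4 (0.68 log units; beyond the scatter), beyond the scatter. Compound 4 is therefore estimated at 3000 nM, within a range of 800 nM to 12000 nM.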

Compound 4, solubility: 32000 nM
The estimate for compound 4 lay 11-fold (1.03 log units) below the measured number, and the stated range ends below it.
By their numbers in this assay, from the lowest: compound 3; then compounds 1 and 2 (each within the scatter of the next); then compound 4.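

In this assay, putting 4-(tert-butyl)phenyl in place of phenoxy on this aromatic carbon gives a 2.2-fold higher number from compound 2 to compound 4 (0.34 log units; beyond the scatter), a modest step, but the only one among these compounds that shows a single change moving the number. The entering group has 10 heavy atoms and 0 hydrogen-bond acceptors, against 7 heavy atoms and 1 hydrogen-bond acceptor for phenoxy, so in this pair more heavy atoms and the loss of that acceptor come with a higher number, not a lower one. No measurement at hand explains this rise.

Still open, going by these compounds, is whether the rise follows from the tert-butyl group or from the loss of the oxygen link, which a plain phenyl at this carbon would help separate. An amine on that phenyl ring would further test how far this position tolerates change.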